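The compounds below may be only part of what the source reports. "The series", "measured", "known", "first", "only" and "open" are said of these compounds alone.

For the measured compounds named here, in a functional assay on KYSE-450 cells (Homo sapiens) for inhibition, read by MTT assay, with a stated time of 48 h (a higher number here means a weaker inhibitor, a lower number a stronger inhibitor), compound 3 `COc1ccc(CNc2cc(OC)c(OC)c(OC)c2)cc1Cl` gives 47800 nM, the weakest of the three compounds measured so far. Compound 1 `COc1ccc(CNc2cc(OC)c(OC)c(OC)c2)cc1[N+](=O)[O-]` gives 16800 nM, and compound 2 `COc1ccc(CN(C(C)=O)c2cc(OC)c(OC)c(OC)c2)cc1O` gives 160 nM.

The next compound, compound 4 `COC(=O)c1cc(CNc2cc(OC)c(OC)c(OC)c2)ccc1OC`, carries methoxycarbonyl in place of chloro on an aromatic carbon, ortho to a methoxy group (methoxycarbonyl in place of chloro on an aromatic carbon). Going by the values given here, only one measured step involves a single change at this carbon, chloro in place of nitro: a 2.8-fold higher number from compound 1 to compound 3 (0.45 log units; beyond the scatter). It is modest, and it offers only a rough guide, since methoxycarbonyl itself has not yet been tested here.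

Taking that step as the best available measure of size, and with compound 3 at the weak end of the numbers, a similarly modest move toward a lower number is expected in this assay. The expected change is a 1.9-fold lower number from compound 3 to compound 4 (0.28 log units; within the scatter). For compound 4 the estimated value is 25000 nM, with an expected range of 8000 nM to 70000 nM.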

Compound 4, half-maximal inhibitory concentration: 41100 nM
Compound 4: the middle estimate sits 1.6-fold (0.22 log units) below what was measured; low and high end bracket the measured number.
By their numbers in this assay, from the lowest: compound 2; then compound 1; then compounds 4 and 3 (each within the scatter of the next).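

In this assay, putting methoxycarbonyl in place of chloro gives a 1.2-fold lower number from compound 3 to compound 4 (0.07 log units; within the scatter), so at this aromatic carbon a group of 4 heavy atoms with 2 hydrogen-bond acceptors cannot be told apart from a single chlorine atom. Set against nitro, the same group gives a 2.4-fold higher number from compound 1 to compound 4 (0.39 log units; beyond the scatter), which puts methoxycarbonyl alongside chloro, and of the three groups tested at this carbon only nitro stands apart from the other two. Nothing measured here explains why these groups compare as they do.

On these data alone, it remains open whether an amine or a carboxylic acid at this carbon would move the number further than these three groups do. Also open, as far as these compounds go, is whether nitro would still stand apart from chloro and methoxycarbonyl on the core of compound 2.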